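A Pyridinylmethyl Replaces Chlorophenyl on the Piperazine Nitrogen

This account rests on a few compounds, and the source may have more. Where it says the series, first, only, none or still open, it means among the compounds named here.

Measured compounds:
compound 1 `Nc1ccccc1NC(=O)c1ccc(CSC(=S)N2CCN(c3ccc(Cl)cc3)CC2)cc1` — 15%
compound 2 `Nc1ccccc1NC(=O)c1ccc(CSC(=S)N2CCCc3ccccc32)cc1` — 38.5%

In a functional assay on MGC-803 cells (Homo sapiens) for antiproliferative activity, read by CCK-8 assay, with a stated time of 72 h, tested at 2 uM (a lower number here means a weaker effect, a higher number a stronger effect of the compound at the concentration tested), compound 1 gives 15%, the lowest of the two numbers; compound 2 gives 38.5%, a gap beyond the usual scatter. Compound 3 `Nc1ccccc1NC(=O)c1ccc(CSC(=S)N2CCN(Cc3cccnc3)CC2)cc1` differs from compound 1 in one place: (pyridin-3-yl)methyl in place of 4-chlorophenyl on an amine nitrogen in a ring. Among the compounds with values here, no measured pair shows this kind of exchange, so its effect is unknown. The step of a number 5 percentage points higher from compound 1 to compound 3 (within the scatter) is expected to be small and not clearly beyond the scatter. Compound 3 is estimated at 20%, within 5% to 40%.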

Compound 3, a percentage reported as inhibition, at one concentration (the size of the read-out at that concentration, not a potency): 37.7%
For compound 3 the middle estimate is 17.7 percentage points below the measured one; the range from low to high includes it.
By their numbers in this assay, from the lowest: compound 1; then compounds 3 and 2 (each within the scatter of the next).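

In this assay, the exchange of 4-chlorophenyl for (pyridin-3-yl)methyl on this amine nitrogen in a ring gives a number 22.7 percentage points higher from compound 1 to compound 3 (beyond the scatter), so the group held at this position can change the read-out. Both groups have the same number of heavy atoms, so that count does not separate them. Nothing measured here gives a reason for the step.

From the compounds shown here alone, the exchange alters both the ring and its link to the nitrogen, so the contribution of each stays open. A plain benzyl group or a pyridin-3-yl group attached directly would separate the two.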